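A few compounds are considered here, and "the series" means these few. Any claim that something is new, unique, unknown or untested is made for them only; others in the source may bear on it.

Measured so far:
compound 1 `CCOC(=O)/C=C/c1ccncc1-c1ccc2c(cnn2C)c1` — > 10000 nM
compound 2 `Cn1ncc2cc(-c3cnccc3/C=C/C(=O)O)ccc21` — > 10000 nM
compound 3 `CCOC(=O)/C=C/c1ccncc1-c1ccc2c(ccn2C)c1` — 10200 nM

In a functional assay on MDA-MB-231 cells (Homo sapiens) for inhibition, read by sulforhodamine B assay, with a stated time of 72 h (on this read-out lower numbers stand for stronger inhibition of growth and higher numbers for weaker inhibition of growth), compound 1 gives only a limit, > 10000 nM. Compound 2 likewise gives only a limit in this assay, > 10000 nM. Going by the values given here, compound 3 is the one compound with a number, giving 10200 nM in this assay. The change from compound 1 to compound 2 is hydrogen in place of ethyl on an oxygen next to a carbonyl group, and its step, a step that the two limits leave unreadable from compound 1 to compound 2, cannot be read because both results sit at the limit of > 10000 nM in this assay, at which 2 of the 3 values shown sit. How the core of compound 1 differs from the core of compound 3 is not broken down here.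

Compound 4 `Cn1ccc2cc(-c3cnccc3/C=C/C(=O)O)ccc21` carries the same change relative to compound 3: hydrogen in place of ethyl on an oxygen next to a carbonyl group. Among the compounds with values here, the one earlier instance gives no size to lean on, so the expectation for compound 4 rests on compound 3 itself, at 10200 nM, with a step of a 1.5-fold higher number from compound 3 to compound 4 (0.17 log units; within the scatter) expected in this assay. Compound 4 is therefore estimated at 15000 nM, within 5000 nM to 50000 nM.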

Compound 4, concentration for 50% growth inhibition: > 10000 nM
Compound 4: a limit, no number; the forecaster's own chance of this, stated with the estimate: 60%; the middle value does not contradict the limit.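

In this assay compound 4 gives only a limit, > 10000 nM, so no size can be read for the change from compound 3 to compound 4, and the result adds to this pile-up: the limit of > 10000 nM in this assay, at which 3 of the 4 values shown sit. The compounds shown leave open whether exchanging ethoxycarbonyl for carboxy changes growth inhibition at all.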